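Swapping methoxy for fluoro at the cytotoxicity limit

The compounds below may be only part of what the source reports. "The series", "measured", "known", "first", "only" and "open" are said of these compounds alone.

In a functional assay on MIA PaCa-2 cells (Homo sapiens) for cytotoxicity, read by WST assay, with a stated time of 48 h (a lower number here means a stronger inhibitor, a higher number a weaker inhibitor), compound 1 (`COc1ccc2c(/C=C(\C#N)C(=O)c3c[nH]c4cc(F)ccc34)c[nH]c2c1`) gives > 50000 nM, which is a limit and not a number. Compound 2 (`COc1ccc2c(/C=C(\C#N)C(=O)c3c[nH]c4cc(OC)ccc34)c[nH]c2c1`) gives > 50000 nM, also a limit. Compound 1 therefore stands at the limit of > 50000 nM in this assay, at which 2 of the 2 values shown sit.

Compound 3 (`N#C/C(=C\c1c[nH]c2cc(F)ccc12)C(=O)c1c[nH]c2cc(F)ccc12`) has fluoro in place of methoxy on an aromatic carbon of the core of compound 1: fluoro in place of methoxy on an aromatic carbon.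

Within the data shown here, the one measured step that bears on this swaps the same two groups: a step that the two limits leave unreadable from compound 1 to compound 2. It gives neither a size nor a direction, so no step beyond the scatter is expected in this assay. The estimated change is a number no higher from compound 1 to compound 3 (the limit leaves the size open), and a further limit is the likeliest outcome. For compound 3 the expected value is 50000 nM, with an estimated range from 15000 nM to 100000 nM.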

Compound 3, half-maximal inhibitory concentration: > 50000 nM
Compound 3 ended at the assay's limit (the forecaster's own chance of this, stated with the estimate: 70%); the middle value sits exactly at the limit.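

Compound 1 and compound 3 both give limits and not numbers, so no step can be read between them. Compound 1, compound 2 and compound 3 share one result: the limit of > 50000 nM in this assay, at which 3 of the 3 values shown sit.

The compounds shown leave open how strongly each acts on these cells, and whether fluoro or methoxy makes any difference.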